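The source may hold more compounds than are shown below. What is called first, only, known or untested is meant among the compounds shown, and "the series" means these compounds.

Measured so far in an assay on HEK293 cells for inhibition of acid ceramidase (Homo sapiens), read by fluorescence, with stated times of 10 min and 3 h; a lower number here means a stronger inhibitor, a higher number a weaker inhibitor:
- compound 1 `CC(C)N1CCN(c2ccc3c(c2)oc(=O)n3C(=O)NCCCCc2ccccc2)CC1`: 211 nM
- compound 2 `O=C(NCCCCc1ccccc1)n1c(=O)oc2cc(C3CCOCC3)ccc21`: 68 nM
- compound 3 `CN1CCN(c2ccc3c(c2)oc(=O)n3C(=O)NCCCCc2ccccc2)C(=O)C1`: 52 nM

Compound 3 gives the lowest number of the three, but its separation from compound 2 is within the scatter, so the two cannot be ranked; only compound 1 stands clearly apart, a 4.1-fold lower number from compound 1 to compound 3 (0.61 log units; beyond the scatter) and a 3.1-fold lower number from compound 1 to compound 2 (0.49 log units; beyond the scatter).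

Compound 4 `CN1CCN(c2ccc3c(c2)oc(=O)n3C(=O)NCCCCc2ccccc2)CC1` differs from compound 3 in one place: 4-methylpiperazin-1-yl in place of 4-methyl-2-oxopiperazin-1-yl on an aromatic carbon. The change removes the carbonyl from the six-membered ring while keeping the methyl on the far nitrogen. For the measured compounds named here, the one measured step that bears on it is a 4.1-fold lower number from compound 1 to compound 3 (0.61 log units; beyond the scatter), where the ring without the carbonyl, bearing isopropyl, gave the higher number. Going by the values given here, compound 4 keeps that carbonyl-free ring but carries methyl instead of isopropyl, a point on which no measured pair gives guidance. The expectation is therefore a step back toward compound 1, of modest size, rather than a gain: in this assay compound 4 is estimated at 130 nM, with a range of 50 nM to 350 nM. This estimate means an expected step of a 2.5-fold higher number from compound 3 to compound 4 (0.40 log units; beyond the scatter).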

Compound 4, half-maximal inhibitory concentration: 116 nM
Compound 4: middle estimate off by 1.1-fold (0.05 log units), on the high side; low and high end bracket the measured number.
By their numbers in this assay, from the lowest: compounds 3, 2, 4 and 1 (each within the scatter of the next, the first and the last beyond it).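

In this assay, the pair of compound 3 and compound 4 isolates the ring carbonyl with the methyl on the far nitrogen held constant, and removing it gives (a 2.2-fold higher number from compound 3 to compound 4 (0.35 log units; beyond the scatter)), whereas the earlier step from the isopropyl compound changed the carbonyl and the nitrogen substituent together. Methyl in place of isopropyl on the ring amine nitrogen does not separate the two compounds (a 1.8-fold lower number from compound 1 to compound 4 (0.26 log units; within the scatter)), so of the two differences between compound 1 and compound 3, only the carbonyl has been shown to give a step beyond the scatter on its own. The 4-methylpiperazin-1-yl and oxan-4-yl groups cannot be ranked (a 1.7-fold higher number from compound 2 to compound 4 (0.23 log units; within the scatter)), so this aromatic carbon tolerates both in this series.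

As far as these compounds go, it remains open whether the number seen with compound 3 would hold with a morpholin-4-yl group, with a piperazine carrying hydrogen on the far nitrogen, or with an acetyl group on that nitrogen in place of the ring carbonyl. No measurement at hand accounts for the step on removing the carbonyl.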